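Replacing 2-chlorophenyl with 4-nitrophenyl on compound 3

The source may hold more compounds than are shown below. What is called first, only, known or untested is meant among the compounds shown, and "the series" means these compounds.

Compound 1 `COc1cc(C(=O)c2cn(-c3cccc(N)c3)cc2-c2ccccc2Cl)cc(OC)c1OC`: 40 nM
Compound 2 `COc1cc(C(=O)c2cn(-c3cccc(N)c3)cc2-c2ccc([N+](=O)[O-])cc2)cc(OC)c1OC`: 110 nM
Compound 3 `COc1cc(C(=O)c2cn(-c3ccc(C)cc3)cc2-c2ccccc2Cl)cc(OC)c1OC`: 180 nM

In a functional assay on MCF7 cells (Homo sapiens) for cytotoxicity, read by MTT assay, with a stated time of 96 h (a lower number here means a stronger inhibitor, a higher number a weaker inhibitor), compound 3 gives 180 nM, within the scatter of compound 2 at 110 nM. Against compound 1 the measured step is a 4.5-fold higher number from compound 1 to compound 3 (0.65 log units; beyond the scatter). Compound 4 `COc1cc(C(=O)c2cn(-c3ccc(C)cc3)cc2-c2ccc([N+](=O)[O-])cc2)cc(OC)c1OC` carries 4-nitrophenyl in place of 2-chlorophenyl on an aromatic carbon. The same exchange has one measured precedent, a 2.8-fold higher number from compound 1 to compound 2 (0.44 log units; beyond the scatter), there with 3-aminophenyl rather than 4-methylphenyl on the aromatic nitrogen. A modest step of similar size towards a higher number is therefore expected in this assay, although a single precedent is thin support. The expected step is a 2.7-fold higher number from compound 3 to compound 4 (0.43 log units; beyond the scatter). Compound 4 is estimated at 480 nM, with an expected range of 200 nM to 1100 nM.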

Compound 4, half-maximal inhibitory concentration: 200 nM
Compound 4: middle estimate off by 2.4-fold (0.38 log units), on the high side, within the range that was stated.
By their numbers in this assay, from the lowest: compound 1; then compounds 2, 3 and 4 (each within the scatter of the next).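

In this assay, 4-nitrophenyl in place of 2-chlorophenyl on the aromatic carbon gives a 1.1-fold higher number from compound 3 to compound 4 (0.05 log units; within the scatter), so with 4-methylphenyl on the aromatic nitrogen this exchange stays within the scatter. Its size on the two cores does not separate beyond the scatter: the same change on two cores in this assay, a 2.8-fold higher number (0.44 log units; beyond the scatter) from compound 1 to compound 2 and a 1.1-fold higher number (0.05 log units; within the scatter) from compound 3 to compound 4, 2.5-fold (0.39 log units) apart, within the scatter of two such steps With 4-nitrophenyl present, 4-methylphenyl in place of 3-aminophenyl gives a 1.8-fold higher number from compound 2 to compound 4 (0.26 log units; within the scatter), and that change does not separate either: the same change on two cores in this assay, a 4.5-fold higher number (0.65 log units; beyond the scatter) from compound 1 to compound 3 and a 1.8-fold higher number (0.26 log units; within the scatter) from compound 2 to compound 4, 2.5-fold (0.39 log units) apart, within the scatter of two such steps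

The exchange alters both substituent and ring position, and 4-chlorophenyl would separate the two. From the compounds shown here alone, how an amine or a carboxylic acid on this phenyl ring would read remains open.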